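A few compounds are considered here, and "the series" means these few. Any claim that something is new, unique, unknown or untested is made for them only; others in the source may bear on it.

Measured so far:
compound 1 `ClCc1ccc(Cn2cnc3nc(Cl)nc(Cl)c32)cc1` — 3890 nM
compound 2 `ClCc1ccccc1Cn1cnc2nc(Cl)nc(Cl)c21` — 5490 nM

Both numbers come from a functional assay on HOP-62 cells (Homo sapiens) for cytotoxicity, read by sulforhodamine B assay, with a stated time of 48 h; on this read-out higher numbers stand for weaker inhibition of growth and lower numbers for stronger inhibition of growth. Compound 1 gives the lower of the two, but its gap to compound 2 lies within the usual scatter, so the pair is read as equivalent. Compound 3 `ClCc1ccc(Cn2cnc3ncnc(Cl)c32)cc1` is not yet measured. It differs from compound 1 by hydrogen in place of chloro on an aromatic carbon — hydrogen in place of chloro on an aromatic carbon. Among the compounds with values here, no step of this kind has been measured, so its size is unknown; a modest weakening of growth inhibition in this assay is expected, possibly no larger than the scatter. For compound 3 the expected value is 8000 nM (range 2500 nM to 25000 nM), an estimated step of a 2.1-fold higher number from compound 1 to compound 3 (0.31 log units; beyond the scatter).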

Compound 3, concentration for total growth inhibition: 3160 nM
Beside the measured number, compound 3's estimate is 2.5-fold (0.40 log units) above it, within the range that was stated.
By their numbers in this assay, from the lowest: compounds 3, 1 and 2 (each within the scatter of the next).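

Hydrogen in place of chloro on the aromatic carbon between two ring nitrogen atoms gives a 1.2-fold lower number from compound 1 to compound 3 (0.09 log units; within the scatter) in this assay and so leaves the pair equivalent. For this pair, the chloro at this carbon is not required for the level of growth inhibition seen with compound 1. No available evidence bears on this result.

Going by these compounds, whether an amine or a methoxy group at this carbon would read the same remains open. So does the contribution of the chloro group meta to this carbon.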